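This account rests on a few compounds, and the source may have more. Where it says the series, first, only, none or still open, it means among the compounds named here.

Compound 1 `C=CCOc1cc(C2=C(c3cc(OC)c(OC)c(OC)c3)C(=O)C(O)C2)ccc1OC` is one of two compounds with the shared core for which a cytotoxicity result is known. In an ADME assay on ECV-304 cells (Homo sapiens) for cytotoxicity, read by MTT assay, with a stated time of 72 h (a higher number here means a weaker inhibitor, a lower number a stronger inhibitor), compound 1 gives > 100 ug/mL, which is a limit of the assay and not a number. Compound 2 `CCOC(=O)COc1ccc(C2=C(c3cc(OC)c(OC)c(OC)c3)C(=O)CC2O)cc1` is the other; in this assay compound 2 gives > 100 ug/mL, again a limit. Compound 1 therefore has no fixed place among the numbers shown: both values sit at the limit of > 100 ug/mL in this assay, at which 2 of the 2 values shown sit, and no step between measured compounds can be counted from them. Compound 3 `COc1ccc(C2=C(c3cc(OC)c(OC)c(OC)c3)C(=O)C(O)C2)cc1Cl` differs from compound 1 by chloro in place of allyloxy on an aromatic carbon. Going by the values given here, since both known values rest at the limit, no size of step in this assay can be read from the data; the expectation is for no step beyond the scatter, with compound 3 likely reported at the limit as well. Compound 3 is therefore expected to give 100 ug/mL in this assay, between 50 ug/mL and 200 ug/mL. The expected step is a number no higher from compound 1 to compound 3 (the limit leaves the size open).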

Compound 3, half-maximal inhibitory concentration: 20 ug/mL
The estimate for compound 3 lay 5.0-fold (0.70 log units) above the measured number, outside the stated range (below it).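

In this assay chloro in place of allyloxy gives an at least 5.0-fold lower number from compound 1 to compound 3 (0.69 log units; beyond the scatter) on this aromatic carbon, ortho to a methoxy group. Going by these compounds alone, this is the first sign that the read-out responds to a change at this place on the shared core, with a step beyond the scatter that the earlier compounds could not show. Compound 3 is the only one of the three with a number, while compound 1 and compound 2 each rest at a limit of the assay and not a number: the limit of > 100 ug/mL in this assay, at which 2 of the 3 values shown sit.

Going by these compounds, the full size of the step stays open, and so does whether it follows from chloro entering or from allyloxy leaving. The compounds shown also leave open how a bromo, a hydroxyl, an amine or a shorter ether such as methoxy would read on this same carbon.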